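The source may report more compounds than this note shows. Statements on the series, on what has been measured and on what is new or still open speak of the compounds shown alone.

Measured compounds in a functional assay on PC-3 cells (Homo sapiens) for antiproliferative activity; a lower number here means a stronger inhibitor, a higher number a weaker inhibitor:
compound 1 `COc1cc(NC(=O)c2cccc(NC(=O)C(C)Br)c2)cc(OC)c1OC` — 2460 nM
compound 2 `COc1cc(NC(=O)c2cc(NC(=O)C(C)Br)ccc2F)cc(OC)c1OC` — 2180 nM

Compound 1 has the highest of the two numbers, and its nearest neighbour is compound 2, separated by a 1.1-fold lower number from compound 1 to compound 2 (0.05 log units; within the scatter). The unmeasured compound 3 `COc1ccc(NC(=O)c2cccc(NC(=O)C(C)Br)c2)cc1OC` differs from compound 1 by hydrogen in place of methoxy on an aromatic carbon. Among the measured compounds shown here, the only measured step concerns a different change, so no measured step bears on this one, and no size of step in this assay can be read off from the data. Compound 3 is therefore expected to give 3000 nM, within 1000 nM to 9000 nM, an expected step of a 1.2-fold higher number from compound 1 to compound 3 (0.09 log units; within the scatter).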

Compound 3, half-maximal inhibitory concentration: 2360 nM
Compound 3: the middle estimate sits 1.3-fold (0.10 log units) above what was measured, and the stated range covers the measured number.
By their numbers in this assay, from the lowest: compounds 2, 3 and 1 (each within the scatter of the next).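

In this assay hydrogen in place of methoxy on an aromatic carbon, ortho to a methoxy group and meta to a large group, gives a 1.0-fold lower number from compound 1 to compound 3 (0.02 log units; within the scatter) and so shows what compound 2 could not: this methoxy group can be lost with the number staying within the scatter. Nothing in hand explains this result.
The compounds shown leave open whether a hydroxyl, an amine or a longer chain such as ethoxy at this position would also stay within the scatter. They also leave open whether the same holds with the fluoro of compound 2 present.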